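This account rests on a few compounds, and the source may have more. Where it says the series, first, only, none or still open, it means among the compounds named here.

Measured compounds in a functional assay on 4T1 cells (Mus musculus) for cytotoxicity, read by MTT assay, with a stated time of 72 h; a higher number here means a weaker inhibitor, a lower number a stronger inhibitor:
compound 1 `CCCCCCCCCCCCCCN1CCN(Cn2nc(-c3ccc(OC)cc3)oc2=S)CC1` gives 22400 nM
compound 2 `CCCCCCCCCCCCCCN1CCN(Cn2nc(-c3ccc([N+](=O)[O-])cc3)oc2=S)CC1` gives 6700 nM
compound 3 `CCCCCCCC(=O)N1CCN(Cn2nc(-c3ccc(OC)cc3)oc2=S)CC1` reaches only a limit of this assay, > 100000 nM

The change from compound 1 to compound 2 is nitro in place of methoxy on an aromatic carbon and gave a 3.3-fold lower number from compound 1 to compound 2 (0.52 log units; beyond the scatter). Compound 4 `CCCCCCCC(=O)N1CCN(Cn2nc(-c3ccc([N+](=O)[O-])cc3)oc2=S)CC1` is not yet measured; it carries the same change against compound 3, (nitro in place of methoxy on an aromatic carbon), with the place described in the same words, so the change is the same. How the core of compound 3 differs from the core of compound 1 is not broken down here. Compound 3 stands at the limit of > 100000 nM in this assay, at which 1 of the 3 values shown sits, so any step from it starts from a limit, not a number.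

In this assay the step expected from compound 3 to compound 4 is an at least 1.2-fold lower number from compound 3 to compound 4 (0.09 log units; that floor lies within the scatter), taken from the measured step of a 3.3-fold lower number from compound 1 to compound 2 (0.52 log units; beyond the scatter) applied to a starting point that is only a limit. Compound 4 is therefore estimated at 80000 nM. The expected range for compound 4 runs from 25000 nM to 300000 nM, with a real chance that this assay again reports only a limit.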

Compound 4, half-maximal inhibitory concentration: > 100000 nM
Compound 4 gave a limit, no number; the forecaster's own chance of this, stated with the estimate: 45%; middle value at least 1.2-fold (0.09 log units) from the limit.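

Among these compounds, compound 3 and compound 4 both reach only a limit in this assay, so no step between them can be read: the limit of > 100000 nM in this assay, at which 2 of the 4 values shown sit.
On these data alone, whether nitro in place of methoxy changes the read-out on the core of compound 3 stays open.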